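Adding a Methyl to the Amino Acid Side Chain

The source may report more compounds than this note shows. Statements on the series, on what has been measured and on what is new or still open speak of the compounds shown alone.

Of the compounds shown here, two have been measured so far. Compound 2 `COc1cc(NC(C)CCCN2C(=O)CN(C(=O)[C@H](N)C(C)C)C2(C)C)c2ncccc2c1` is one of them: in an ADME assay on A549 cells (Homo sapiens) for cytotoxicity, with a stated time of 72 h (on this read-out lower numbers stand for stronger inhibition and higher numbers for weaker inhibition), compound 2 gives 5500 nM. Within the data shown here, its only neighbour is compound 1 `COc1cc(NC(C)CCCN2C(=O)CN(C(=O)[C@H](N)CCSC)C2(C)C)c2ncccc2c1`, and in this assay compound 1 gives 7900 nM; the two numbers lie within the scatter of each other, as the step of a 1.4-fold lower number from compound 1 to compound 2 (0.16 log units; within the scatter) shows. Compound 3 `CC[C@H](C)[C@@H](N)C(=O)N1CC(=O)N(CCCC(C)Nc2cc(OC)cc3cccnc23)C1(C)C` carries methyl in place of hydrogen on a saturated chain carbon, three bonds along the chain from an amine nitrogen and a carbonyl carbon. That single step touched the same side chain and stayed within the scatter, so the step of no change at the digits printed from compound 2 to compound 3 (within the scatter) is expected to stay within the scatter too. Compound 3 is therefore estimated at 5500 nM, with a range of 2500 nM to 12000 nM.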

Compound 3, half-maximal inhibitory concentration in the A549 assay: 14900 nM
For compound 3 the middle estimate is 2.7-fold (0.43 log units) below the measured one; measured number outside the range, above it.
By their numbers in the A549 assay, from the lowest: compounds 2, 1 and 3 (each within the scatter of the next, the first and the last beyond it).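

In the A549 assay, this side chain position now gives its first step beyond the scatter, and a single added methyl is enough: a 2.7-fold higher number from compound 2 to compound 3 (0.43 log units; beyond the scatter). Set against the 2-(methylsulfanyl)ethyl side chain, sec-butyl stays within the scatter, a 1.9-fold higher number from compound 1 to compound 3 (0.28 log units; within the scatter), so the effect of the methyl is only visible against isopropyl. In a physicochemical assay for lipophilicity, measured as octanol-water partition (a lower number here means a more polar compound, a higher number a more lipophilic compound), compound 2 gives 2.93 and compound 3 gives 3.4 on the same read-out. The same methyl also makes compound 3 more lipophilic than compound 2: the measured partition coefficient of compound 2, 2.93, and of compound 3, 3.4, a number 0.47 log units higher (beyond the scatter)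

A single pair cannot tell whether these two shifts are linked. A side chain carrying a hydroxyl group or a carboxylic acid at this position could help separate them.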